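The source may report more compounds than this note shows. Statements on the series, on what has been measured and on what is new or still open speak of the compounds shown alone.

Measured in a functional assay on HepG2 cells (Homo sapiens) for antiproliferative activity, read by MTT assay, with a stated time of 48 h; on this read-out higher numbers stand for an effect only at larger amounts of compound and lower numbers for an effect already at smaller amounts:

Compound 1 `CC1=NN(C(=O)c2ccc(F)cc2)C(c2ccccc2O)C1`: 39200 nM
Compound 2 `CC1=NN(S(=O)(=O)c2ccc([N+](=O)[O-])cc2)C(c2cc(Br)ccc2O)C1`: > 60000 nM

On these data alone, for compound 2 the value > 60000 nM is a limit of the assay and not a number, so its true position is unknown. Compound 3 `CC1=NN(S(=O)(=O)c2ccc(Cl)cc2)C(c2cc(Br)ccc2O)C1` has chloro in place of nitro on an aromatic carbon, para to a large group: chloro in place of nitro on an aromatic carbon. Going by the values given here, no measured step bears on this change. A modest move toward lower numbers is expected, staying in the range set by compound 1 at 39200 nM. The estimated change is an at least 1.5-fold lower number from compound 2 to compound 3 (0.17 log units; that floor lies within the scatter). Compound 3 is expected at 40000 nM, with an estimated range of 15000 nM to 90000 nM.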

Compound 3, half-maximal effective concentration: > 60000 nM
Compound 3: a limit, no number (the forecaster's own chance of this, stated with the estimate: 35%); at least 1.5-fold (0.17 log units) between middle value and limit.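

Compound 2 and compound 3 both stand at a limit of the assay and not at a number, so no step can be read between them. On these data alone, whether chloro in place of nitro shifts the effect in this assay stays open.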